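Trading a ring for a short chain on the amide nitrogen

The compounds below may be only part of what the source reports. "The series", "measured", "known", "first", "only" and "open" are said of these compounds alone.

Measured compounds:
compound 1, `CC(=O)Nc1cccc(-c2cc(C(=O)N[C@H]3CCCNC3)c(NC(N)=O)s2)c1`, 1800 nM in a functional assay on HT-29 cells (Homo sapiens); a lower number here means that less compound is needed, a higher number that more compound is needed for the effect
compound 2, `NC(=O)Nc1sc(-c2ccc(C(=O)N3CCOCC3)cc2)cc1C(=O)N[C@H]1CCCNC1`, 610 nM in this assay
compound 3, `NC(=O)Nc1sc(-c2ccccc2)cc1C(=O)NC1CCNCC1`, "not determined" (no result reported) in this assay

Compound 3 has no number of its own in this assay, so its standing can only be judged from its relatives, compound 1 and compound 2, which share its core and fall in the high-nanomolar range. The unmeasured compound 4, `NCCNC(=O)c1cc(-c2ccccc2)sc1NC(N)=O`, arises from compound 3 through a single change: 2-aminoethyl in place of piperidin-4-yl on an amide-type nitrogen. Among the compounds with values here, with no measured step to compare against, the expectation rests on the values of compound 1 and compound 2 alone, and a shift in either direction beyond the scatter is possible. Compound 4 is expected to give about 2500 nM in this assay, within a range from 500 nM to 12000 nM.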

Compound 4, half-maximal effective concentration: 960 nM
Estimate against measurement, compound 4: 2.6-fold (0.42 log units) above; low and high end bracket the measured number.
By their numbers in this assay, from the lowest: compounds 2, 4 and 1 (each within the scatter of the next, the first and the last beyond it).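

In this assay compound 4 gives 960 nM, but no step from compound 3 can be read, and no supporting data explain this value.

Left open is how replacing piperidin-4-yl with 2-aminoethyl on the amide-type nitrogen shifts the value.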